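Replacing the nitrophenyl ketone group with an aminopyrimidinyl ketone

This account rests on a few compounds, and the source may have more. Where it says the series, first, only, none or still open, it means among the compounds named here.

Measured compounds:
Compound 1 `COc1ccc(-c2cc3ccccc3nc2/C=C/C(=O)c2ccc([N+](=O)[O-])cc2)cc1`: 4110 nM
Compound 2 `COc1ccc(-c2cc3ccccc3nc2/C=C/C(=O)c2cccs2)cc1`: 1030 nM

Of the compounds shown here, two have been measured in a functional assay on MCF7 cells (Homo sapiens) for antiproliferative activity, read by XTT assay, with a stated time of 72 h; on this read-out higher numbers stand for weaker inhibition and lower numbers for stronger inhibition. Compound 1 `COc1ccc(-c2cc3ccccc3nc2/C=C/C(=O)c2ccc([N+](=O)[O-])cc2)cc1` gives 4110 nM, the highest of the two numbers; its nearest neighbour is compound 2 `COc1ccc(-c2cc3ccccc3nc2/C=C/C(=O)c2cccs2)cc1`, which gives 1030 nM. For the measured compounds named here, the only measured step, a 4.0-fold lower number from compound 1 to compound 2 (0.60 log units; beyond the scatter), is the one that bears on the question. Compound 3 `COc1ccc(-c2cc3ccccc3nc2/C=C/C(=O)c2cnc(N)nc2C)cc1` differs from compound 1 in one place: 2-amino-4-methylpyrimidin-5-yl in place of 4-nitrophenyl on a carbonyl carbon. Going by the values given here, the measured step shows that exchanging the 4-nitrophenyl for another aromatic group on that carbonyl carbon produced a modest lowering in this assay; no step involving a 2-amino-4-methylpyrimidin-5-yl group has been measured, so the size of the effect of this particular group is uncertain. Compound 3 is therefore expected to show a step of about a 1.4-fold lower number from compound 1 to compound 3 (0.14 log units; within the scatter) in this assay, with a wide range. The estimate for compound 3 is 3000 nM, between 800 nM and 12000 nM.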

Compound 3, half-maximal inhibitory concentration: > 10000 nM
Compound 3: no number, only a limit; the forecaster's own chance of this, stated with the estimate: 10%; middle value at least 3.3-fold (0.52 log units) from the limit.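

Compound 3 gives no number in this assay, only a limit of the assay: the limit of > 10000 nM in this assay, at which 1 of the 3 values shown sits. Even so, the limit is enough to place the change, which gives an at least 2.4-fold higher number from compound 1 to compound 3 (0.38 log units; beyond the scatter) and, set against the thiophen-2-yl group, an at least 9.7-fold higher number from compound 2 to compound 3 (0.98 log units; beyond the scatter). For the compounds shown here, the only earlier step had gone to a lower number, so these steps show that exchanging one aromatic group for another on this carbonyl carbon can move the number in either direction, and that the 2-amino-4-methylpyrimidin-5-yl group lies on the unfavourable side of both other groups.

Going by these compounds, how far compound 3 lies past its limit remains open. Also open, on these data alone, is which part of the entering group goes with the higher number, a question that a plain phenyl or a 4-aminophenyl group on the same carbonyl carbon could begin to address.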